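Trading a small sulfonyl group for a benzoyl group

This account rests on a few compounds, and the source may have more. Where it says the series, first, only, none or still open, it means among the compounds named here.

Of the compounds shown here, three sharing one core have been measured in a functional assay (plasma) for inhibition, with Oryctolagus cuniculus as the target; on this read-out lower numbers stand for stronger inhibition and higher numbers for weaker inhibition. Compound 1 `CCc1ccc(S(=O)(=O)N[C@H]2C3CC[C@H](C3)[C@@H]2C/C=C\CCCC(=O)O)cc1` gives 4600 nM, compound 2 `O=C(O)CCC/C=C\C[C@H]1[C@@H]2CCC(C2)[C@@H]1NS(=O)(=O)CCc1ccccc1` gives 8200 nM, and compound 3 `CS(=O)(=O)N[C@H]1C2CC[C@H](C2)[C@@H]1C/C=C\CCCC(=O)O` gives 640000 nM. Compound 3 is the weakest inhibitor of the three: its number is the highest, and the steps of a 140-fold higher number from compound 1 to compound 3 (2.14 log units; beyond the scatter) and a 78-fold higher number from compound 2 to compound 3 (1.89 log units; beyond the scatter) are both large and well beyond the scatter.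

The next compound, compound 4 `O=C(O)CCC/C=C\C[C@H]1[C@@H]2CCC(C2)[C@@H]1NC(=O)c1ccccc1`, changes compound 3 in one place: benzoyl in place of methylsulfonyl on an amine nitrogen. The two large steps above bear on this change, since each shows that losing a group carrying an aromatic ring from the sulfonyl side of the molecule weakens inhibition sharply. For the measured compounds named here, compound 4 brings such a ring back, though attached through a carbonyl rather than a sulfonyl, a swap for which no measured pair exists. A large step toward stronger inhibition in this assay is therefore expected, but smaller and less certain than those seen with the sulfonyl compounds. For compound 4 the expected value is 20000 nM, within a range of 3000 nM to 200000 nM, which would mean an estimated step of a 32-fold lower number from compound 3 to compound 4 (1.51 log units; beyond the scatter).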

Compound 4, half-maximal inhibitory concentration: > 800000 nM
Compound 4: only a limit was reported; the forecaster's own chance of this, stated with the estimate: 5%; at least 40-fold (1.60 log units) between middle value and limit.
By their numbers in this assay, from the lowest: compounds 1 and 2 (each within the scatter of the next); then compound 3. At a limit, above all of these: compound 4.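

Putting a ring back on the amine nitrogen through a carbonyl brought no gain over the methylsulfonyl group: an at least 1.2-fold higher number from compound 3 to compound 4 (0.09 log units; that floor lies within the scatter). Going by these compounds, the value of compound 4 in this assay is a limit and not a number, so the size of the step remains unknown, and its floor does not separate compound 4 from compound 3: the limit of > 800000 nM in this assay, at which 1 of the 4 values shown sits. The earlier compounds shown here linked an aromatic ring to stronger inhibition only where a sulfonyl group also stood in the molecule, and compound 4 shows that a benzoyl group does not repeat that effect here.

Still open, on these data alone, is whether this holds for carbonyl groups in general or for benzoyl alone. A 4-ethylbenzoyl group or a 3-phenylpropanoyl group on the amine nitrogen would compare directly with the sulfonyl groups of compound 1 and compound 2.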